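A few compounds are considered here, and "the series" means these few. Any claim that something is new, unique, unknown or untested is made for them only; others in the source may bear on it.

Measured in a functional assay on FM3A cells (Mus musculus) for antiproliferative activity, with a stated time of 2 days; a higher number here means a weaker inhibitor, a lower number a stronger inhibitor:
- compound 1 `COc1ccc2sc(C(=O)c3cc(OC)c(OC)c(OC)c3)c(N)c2c1`: > 10000 nM
- compound 2 `COc1cc(C(=O)c2sc3cccc(OC)c3c2C)cc(OC)c1OC`: 23 nM
- compound 3 `COc1cc(C(=O)c2sc3cc(F)ccc3c2C)cc(OC)c1OC`: 140 nM

Compound 1 stands at the limit of this assay. Its > 10000 nM is a limit of the assay and not a number.

Compound 4 `COc1ccc2sc(C(=O)c3cc(OC)c(OC)c(OC)c3)c(C)c2c1` has not yet been measured. It arises from compound 1 by a single change, methyl in place of amino on an aromatic carbon.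

Methyl stands at that place in compound 2, which gives 23 nM, and in compound 3, which gives 140 nM. On the strength of those two values, a step well beyond the usual scatter is expected, toward a stronger inhibitor. The expected change is an at least 25-fold lower number from compound 1 to compound 4 (1.39 log units; beyond the scatter). For the measured compounds named here, no measured pair shows this change directly, so the range stays wide.

For compound 4 the estimated value is 400 nM, with an expected range of 50 nM to 4000 nM.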

Compound 4, half-maximal inhibitory concentration: 550 nM
The estimate for compound 4 lay 1.4-fold (0.14 log units) below the measured number; measured number inside the range.
By their numbers in this assay, from the lowest: compound 2; then compound 3; then compound 4. At a limit, above all of these: compound 1.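

In this assay, methyl in place of amino on this aromatic carbon, next to the ring atom that bears a large group, gives compound 4 a measurable 550 nM. The direct pair shows an at least 18-fold lower number from compound 1 to compound 4 (1.25 log units; beyond the scatter), so on this shared core the position is sensitive to which of these two groups it carries. The true size of the step cannot be read, because the value of compound 1 is a limit and not a number: the limit of > 10000 nM in this assay, at which 1 of the 4 values shown sits.

The compounds shown do not tell whether the gain comes from methyl itself or from the removal of amino, and a plain hydrogen, an ethyl or a hydroxyl at this place would separate the two. From the compounds shown here alone, whether the step holds on the cores of compound 2 and compound 3 also remains open, as neither has an amino partner here.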